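Trifluoromethylphenyl in Place of Thiophene: Expected Cytotoxicity

The source may hold more compounds than are shown below. What is called first, only, known or untested is meant among the compounds shown, and "the series" means these compounds.

Compound 1 `COc1ccc2ccc(=O)oc2c1C1=NN(c2ccccc2)C(c2ccc(SC)cc2)C1` gives 78 nM in a functional assay on HepG2 cells (Homo sapiens) for cytotoxicity, read by MTT assay, with a stated time of 72 h; a higher number here means a weaker inhibitor, a lower number a stronger inhibitor.
Compound 2 `COc1ccc2ccc(=O)oc2c1C1=NN(c2ccccc2)C(c2ccccc2)C1` gives 73 nM in this assay.
Compound 3 `COc1ccc2ccc(=O)oc2c1C1=NN(c2ccccc2)C(c2cccs2)C1` gives 15 nM in this assay.

Among these three, compound 3 stands with the lowest number, that is, as the strongest inhibitor. The steps that lead to it are a 5.2-fold lower number from compound 1 to compound 3 (0.72 log units; beyond the scatter) and a 4.9-fold lower number from compound 2 to compound 3 (0.69 log units; beyond the scatter); both show that replacing a six-membered carbon ring on the saturated ring carbon with thiophen-2-yl gave a clearly lower number. By contrast, a 1.1-fold lower number from compound 1 to compound 2 (0.03 log units; within the scatter) shows that a group on that six-membered ring made little difference.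

Compound 4 `COc1ccc2ccc(=O)oc2c1C1=NN(c2ccccc2)C(c2ccc(C(F)(F)F)cc2)C1` reverses this kind of change: 4-(trifluoromethyl)phenyl in place of thiophen-2-yl on a saturated ring carbon. The two steps toward thiophen-2-yl were each modest and in the same direction. The step back to a six-membered carbon ring is expected to undo them, giving a higher number, close to those of compound 1 and compound 2. The expected step is a 4.7-fold higher number from compound 3 to compound 4 (0.67 log units; beyond the scatter). Compound 4 is therefore estimated at 70 nM in this assay, with a likely range from 30 nM to 170 nM.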

Compound 4, half-maximal inhibitory concentration: 38 nM
For compound 4 the middle estimate is 1.8-fold (0.27 log units) above the measured one, and the stated range covers the measured number.
By their numbers in this assay, from the lowest: compound 3; then compounds 4, 2 and 1 (each within the scatter of the next, the first and the last beyond it).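

With 4-(trifluoromethyl)phenyl on this saturated ring carbon, thiophen-2-yl still gives the lowest number (a 2.5-fold higher number from compound 3 to compound 4 (0.40 log units; beyond the scatter)), so the gap now holds against a third six-membered aromatic ring, though this step is smaller than the two seen before. The group on the six-membered ring also looks less neutral than the first pair suggested. Trifluoromethyl in place of hydrogen stays inside the scatter (a 1.9-fold lower number from compound 2 to compound 4 (0.28 log units; within the scatter)), whereas trifluoromethyl in place of methylsulfanyl goes just beyond it (a 2.1-fold lower number from compound 1 to compound 4 (0.31 log units; beyond the scatter)).

The compounds shown leave open whether an amine or a carboxylic acid on that six-membered ring would shift the number further, and whether a furan ring could stand in for thiophen-2-yl. Nothing available here explains why thiophen-2-yl gives the lowest number.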